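This account rests on a few compounds, and the source may have more. Where it says the series, first, only, none or still open, it means among the compounds named here.

Measured in a functional assay on HL-60 cells (Homo sapiens), read by MTT assay, with a stated time of 72 h; on this read-out lower numbers stand for stronger inhibition of growth and higher numbers for weaker inhibition of growth:
Compound 1 `Cc1cc(F)ccc1C1=Nc2c(Cl)cccc2SC(C(=O)O)C1` gives > 10000000 nM, which is a limit of the assay.
Compound 2 `COc1ccc2c(c1)SC(C(=O)O)CC(c1ccc(F)cc1C)=N2` gives > 10000000 nM, also a limit.

Compound 1 thus stands only at a limit in this assay, and the other value shown is a limit as well (the limit of > 10000000 nM in this assay, at which 2 of the 2 values shown sit). Compound 3 `Cc1cc(F)ccc1C1=Nc2c(F)cccc2SC(C(=O)O)C1` differs from compound 1 by fluoro in place of chloro on an aromatic carbon. No step between measured compounds is available, so the size of this change cannot be read from the data; nothing shown points to growth inhibition appearing, and the expected step is a number no higher from compound 1 to compound 3 (the limit leaves the size open), none beyond the scatter. Compound 3 is therefore estimated at 10000000 nM, within 3000000 nM to 30000000 nM, most likely reported again as a limit.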

Compound 3, concentration for 50% growth inhibition: 6600000 nM
Estimate against measurement, compound 3: 1.5-fold (0.18 log units) above, and the stated range covers the measured number.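

In this assay, going by these compounds alone, compound 3 gives 6600000 nM, the only value shown that is a number and not a limit, so growth inhibition can be read at this aromatic carbon with fluoro in place of chloro. The change gives an at least 1.5-fold lower number from compound 1 to compound 3 (0.18 log units; that floor lies within the scatter). Its true size cannot be read, because compound 1 stands at a limit: the limit of > 10000000 nM in this assay, at which 2 of the 3 values shown sit.

Going by these compounds, whether an amine or a nitrile on this aromatic carbon would give a lower number stays open. So does whether fluoro in place of chloro would give a readable number on any other core.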